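Amino added to a benzyl chloropurine at the assay limit

A few compounds are considered here, and "the series" means these few. Any claim that something is new, unique, unknown or untested is made for them only; others in the source may bear on it.

Compound 1 `ClCc1ccc(Cn2cnc3c(Cl)ncnc32)cc1` gives 9330 nM in a functional assay on SF-268 cells (Homo sapiens) for cytotoxicity, read by sulforhodamine B assay, with a stated time of 48 h; a higher number here means that more compound is tolerated, a lower number that less compound is tolerated. Compound 2 `ClCc1cccc(Cn2cnc3c(Cl)ncnc32)c1` gives a reading that is only a limit of this assay, > 100000 nM. Compound 3 `ClCc1ccccc1Cn1cnc2ncnc(Cl)c21` likewise gives only a limit, > 100000 nM.

Compound 2 therefore stands at the edge of what this assay can report: its reading is not a number but the limit, and the same holds for compound 3, so that two of the three values shown share this point, as the limit of > 100000 nM in this assay, at which 2 of the 3 values shown sit, states. Only compound 1 gives a measured number. Among the compounds with values here, none of the three pairs differs in just one place, so no counted step between measured compounds is available, and nothing beyond these three readings is known about how changes on this shared core move the result.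

Compound 4 `Nc1nc(Cl)c2ncn(Cc3cccc(CCl)c3)c2n1` is the next compound to be measured. It differs from compound 2 by amino in place of hydrogen on an aromatic carbon. Within the data shown here, with compound 2 sitting at the limit, the step from it cannot be counted from below, and no measured pair tells what an amino group at this position does. The expected step of a number no higher from compound 2 to compound 4 (the limit leaves the size open) is therefore taken as none beyond the scatter, with the direction open. Compound 4 is estimated to give 100000 nM, between 30000 nM and 300000 nM.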

Compound 4, concentration lethal to 50% of the cells: 67600 nM
Estimate against measurement, compound 4: 1.5-fold (0.17 log units) above, within the range that was stated.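

Amino on the aromatic carbon between two ring nitrogen atoms gives a reading that this assay can report as a number: compound 4 gives (67600 nM). Compound 2 has only a limit of the assay (> 100000 nM). This gives the first counted step on the shared core (an at least 1.4-fold lower number from compound 2 to compound 4 (0.17 log units; that floor lies within the scatter)), but it is only a floor and the true size of the change stays unknown, because the starting value is a limit and not a number: the limit of > 100000 nM in this assay, at which 2 of the 4 values shown sit.

The compounds shown do not tell whether another group on this carbon, such as methylamino, hydroxyl or a longer amine chain, would give a reading like that of compound 4. They also leave open whether amino at the same place would move the reading in the same way on compound 1, which has a measured number, or on compound 3, which stands at the limit.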